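Trading Ethyl for Methylsulfonyl in a Cytotoxicity Test

This account rests on a few compounds, and the source may have more. Where it says the series, first, only, none or still open, it means among the compounds named here.

In an ADME assay on L6 cells (Rattus norvegicus) for cytotoxicity, read by fluorescence and resazurin assay, with a stated time of 72 h (on this read-out lower numbers stand for higher toxicity in this test and higher numbers for lower toxicity in this test), compound 1 `CCc1ccc(-c2c[nH]cc2C(c2ccc(Cl)cc2Cl)n2ccnc2)cc1` gives 13400 nM and compound 2 `Clc1ccc(C(c2c[nH]cc2-c2ccc(Cl)cc2-c2ccccc2)n2ccnc2)cc1` gives 14900 nM, two numbers within the usual scatter of each other. Compound 3 `CS(=O)(=O)c1ccc(-c2c[nH]cc2C(c2ccc(Cl)cc2Cl)n2ccnc2)cc1` keeps the core of compound 1 but carries methylsulfonyl in place of ethyl on an aromatic carbon. Among the measured compounds shown here, no measured pair of compounds shows what this swap does in this assay. A modest move toward higher numbers, meaning lower toxicity in this test, is still expected. The estimated step is a 2.1-fold higher number from compound 1 to compound 3 (0.32 log units; beyond the scatter). For compound 3 the expected value is 28000 nM, with a range from 11000 nM to 70000 nM.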

Compound 3, half-maximal cytotoxic concentration: 68000 nM
The estimate for compound 3 lay 2.4-fold (0.39 log units) below the measured number; measured number inside the range.
By their numbers in this assay, from the lowest: compounds 1 and 2 (each within the scatter of the next); then compound 3.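

In this assay, methylsulfonyl in place of ethyl gives a 5.1-fold higher number from compound 1 to compound 3 (0.71 log units; beyond the scatter), the first step seen at this position on the aromatic ring. Changing this one group is therefore enough to shift the read-out toward lower toxicity in this test. No measurement here explains why the number rises.

A single pair cannot show whether this shift is particular to methylsulfonyl. Going by these compounds, it remains open whether an amine or a carboxylic acid at the same place would move the number in the same direction, or by a similar amount.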